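The source may report more compounds than this note shows. Statements on the series, on what has been measured and on what is new or still open speak of the compounds shown alone.

Working notes on a small series examined in an ADME assay on HEp-2 cells (Homo sapiens) for cytotoxicity, read by CCK-8 assay, with a stated time of 6 days; on this read-out higher numbers stand for lower toxicity in this test and lower numbers for higher toxicity in this test. Compound 1 `O=c1n(Cc2nc3ccc(Cl)cn3c2CCCCO)c2cnccc2n1C1CC1` returns only a limit in this assay, giving > 100000 nM. Compound 2 `Cc1ccn2c(CCCCO)c(Cn3c(=O)n(C4CC4)c4ccncc43)nc2c1` likewise returns only a limit in this assay, giving > 100000 nM. Compound 3 `O=c1n(Cc2nc3cc(Cl)ccn3c2CO)c2cnccc2n1C1CC1` also returns only a limit in this assay, giving > 100000 nM. All three measured compounds therefore rest together on (the limit of > 100000 nM in this assay, at which 3 of the 3 values shown sit), and no numbered value separates them; compound 3 stands nowhere in particular within the measured set, simply on the shared limit with no ordering possible. Among the measured compounds shown here, no step between measured compounds is recorded.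

Compound 4 `CS(=O)(=O)c1ccc(-c2c(Cn3c(=O)n(C4CC4)c4ccncc43)nc3cc(Cl)ccn23)cc1` is the next member to be measured in this assay. Relative to compound 3 the change is 4-(methylsulfonyl)phenyl in place of hydroxymethyl on an aromatic carbon. With every measured compound on the limit, the series offers no basis for any step beyond the scatter. The expected step of a number no higher from compound 3 to compound 4 (the limit leaves the size open) is accordingly none beyond the scatter. Compound 4 is estimated at 100000 nM in this assay, within a range from 30000 nM to 300000 nM, and is expected most probably to return only a limit again.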

Compound 4, half-maximal cytotoxic concentration: > 100000 nM
Compound 4 was reported as a limit; the forecaster's own chance of this, stated with the estimate: 70%; the middle value sits exactly at the limit.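

Among the compounds shown here, compound 3 and compound 4 each return only a limit in this assay, so no step between them can be read. The compounds shown leave open how any of the four would compare on a numbered value, all of them resting on one limit: the limit of > 100000 nM in this assay, at which 4 of the 4 values shown sit.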